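The source may report more compounds than this note shows. Statements on the series, on what has been measured and on what is new or still open speak of the compounds shown alone.

The measured compounds and their numbers:

Compound 1, `CCCOC(=O)C1=C(C)NC(=O)NC1c1ccco1`, in an assay on membranes from HeLa cells for displacement of a labelled ligand from adenosine receptor A3 (Homo sapiens), read by scintillation counting, with a stated time of 180 min, tested at 1 uM; a higher number here means more inhibition at the concentration tested (going by the name of the read-out), a lower number less inhibition: compound 1 gives 3%.
Compound 2, `CCCOC(=O)C1=C(C)NC(=O)NC1c1ccsc1`, in this assay: compound 2 gives 6%.
Compound 3, `CCCOC(=O)C1=C(C)N(C)C(=O)NC1c1ccsc1`, in this assay: compound 3 gives 11%.

Compound 2 sits second highest of the three numbers. Its nearest neighbour is compound 1, with a step of a number 3 percentage points higher from compound 1 to compound 2 (within the scatter); its furthest is compound 3, with a step of a number 5 percentage points higher from compound 2 to compound 3 (within the scatter). Neither step reaches beyond the scatter, so all three compounds are, in effect, indistinguishable in this assay.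

Compound 4, `CC1=C(C(=O)OCC2CC2)C(c2ccsc2)NC(=O)N1`, differs from compound 2 in one place: cyclopropyl in place of ethyl on a saturated chain carbon bound to an oxygen next to a carbonyl group. Among the compounds with values here, no measured step touches the ester chain, so nothing bears directly on this change. The two steps that are known, at other places on the shared core, were both within the scatter, and the whole set shows only low inhibition. The step from compound 2 to compound 4 is therefore expected to be no change at the digits printed from compound 2 to compound 4 (within the scatter), that is, no change beyond the scatter. For compound 4 the estimate in this assay is 6%, with a range from 0% to 16%.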

Compound 4, a percentage reported as inhibition, at one concentration (the size of the read-out at that concentration, not a potency): 3%
Estimate against measurement, compound 4: 3 percentage points above, within the range that was stated.
By their numbers in this assay, from the lowest: compounds 1, 4, 2 and 3 (each within the scatter of the next).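

In this assay, the ester chain is changed for the first time among these compounds, and cyclopropyl in place of ethyl gives a number 3 percentage points lower from compound 2 to compound 4 (within the scatter). Compound 2 and compound 4 therefore cannot be told apart, so this position joins the two places changed earlier in showing no step beyond the scatter, even with the three-membered ring entering on the saturated chain carbon bound to an oxygen next to a carbonyl group. Nothing available accounts for this result.

The compounds shown leave open whether a longer chain or a chain ending in an amine at this position would give a step beyond the scatter. They also leave open whether a carboxylic acid in place of the ester would change the number in this assay.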